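A few compounds are considered here, and "the series" means these few. Any claim that something is new, unique, unknown or untested is made for them only; others in the source may bear on it.

Compound 1 `O=C(CSc1nnc(-c2ccncc2)o1)N/N=C/c1ccc(Cl)cc1` is the reference point of this set. In a functional assay on SW 1116 cells (Homo sapiens) for cytotoxicity, read by MTT assay, with a stated time of 48 h (on this read-out higher numbers stand for weaker inhibition and lower numbers for stronger inhibition), compound 1 gives 17000 nM, the highest of the three numbers measured. Compound 2 `O=C(CSc1nnc(-c2ccncc2)o1)N/N=C/c1cc(Cl)ccc1O` gives 5240 nM and compound 3 `COc1cc(/C=N/NC(=O)CSc2nnc(-c3ccncc3)o2)ccc1O` gives 3590 nM; the steps of a 3.2-fold lower number from compound 1 to compound 2 (0.51 log units; beyond the scatter) and a 4.7-fold lower number from compound 1 to compound 3 (0.68 log units; beyond the scatter) both bring modestly lower numbers, while a 1.5-fold lower number from compound 2 to compound 3 (0.16 log units; within the scatter) stays within the scatter. Compound 4 `O=C(CSc1nnc(-c2ccncc2)o1)N/N=C/c1ccco1` differs from compound 1 by furan-2-yl in place of 4-chlorophenyl on a carbon with a double bond to nitrogen. Among the compounds with values here, no measured step places furan-2-yl on this carbon, so the two steps away from compound 1 are the only guide; both point to lower numbers, yet each enters a ring bearing a hydroxy, which furan-2-yl does not. Compound 4 is therefore expected to show a small step of a 1.7-fold lower number from compound 1 to compound 4 (0.23 log units; within the scatter). For compound 4 the estimate is 10000 nM, between 4000 nM and 25000 nM.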

Compound 4, half-maximal inhibitory concentration: 18800 nM
For compound 4 the middle estimate is 1.9-fold (0.27 log units) below the measured one, and the stated range covers the measured number.
By their numbers in this assay, from the lowest: compounds 3 and 2 (each within the scatter of the next); then compounds 1 and 4 (each within the scatter of the next).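

Furan-2-yl and 4-chlorophenyl on this carbon cannot be told apart (a 1.1-fold higher number from compound 1 to compound 4 (0.04 log units; within the scatter)), so a five-membered aromatic ring with 1 hetero atom serves here as the six-membered carbon ring does. Furan-2-yl does not share the lower numbers of the hydroxy-bearing rings (a 5.2-fold higher number from compound 3 to compound 4 (0.72 log units; beyond the scatter); a 3.6-fold higher number from compound 2 to compound 4 (0.55 log units; beyond the scatter)), and among these four compounds only those two rings go with lower numbers. No evidence is available to explain this result. Going by these compounds, what a plain 4-hydroxyphenyl or a 4-aminophenyl would give on this carbon stays open, so the hydroxy cannot yet be separated from the chlorine and methoxy that accompany it.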